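The source may hold more compounds than are shown below. What is called first, only, known or untested is meant among the compounds shown, and "the series" means these compounds.

Working notes on the series, read in a functional assay on HepG2 cells (Homo sapiens) for antiproliferative activity, read by MTT assay, with a stated time of 72 h; a lower number here means a stronger inhibitor, a higher number a weaker inhibitor. Compound 1 (`CN(C)CCn1cccc1/C=N/NC(=O)Nc1ccc(Oc2ccnc3[nH]ccc23)cc1`) is recorded as "not active" (no number reported), with no number reported. Among the compounds with values here, compound 2 (`CN(C)CCCn1cccc1/C=N/NC(=O)Nc1ccc(Oc2ccnc3[nH]ccc23)cc1`) gives 4190 nM, the only number so far, so it cannot yet be ranked against another numerical value.

Compound 3 (`CN1CCN(CCCn2cccc2/C=N/NC(=O)Nc2ccc(Oc3ccnc4[nH]ccc34)cc2)CC1`) is the next entry. It departs from compound 2 by one change: 4-methylpiperazin-1-yl in place of dimethylamino on a saturated chain carbon, three bonds along the chain from an aromatic nitrogen. In words, 3-(dimethylamino)propyl becomes 3-(4-methylpiperazin-1-yl)propyl, with the shared core unchanged.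

Within the data shown here, no measured pair differs in a single place, so this assay offers no direct precedent for the size or direction of this change. The estimate therefore rests on compound 2 at 4190 nM as its only numerical anchor. The expected 1.2-fold lower number from compound 2 to compound 3 (0.08 log units; within the scatter) stays within the usual scatter, with no firm direction. A result without a number also remains possible, as seen for compound 1 with "not active" (no number reported).

For compound 3 the estimated value is 3500 nM, with an expected range of 1200 nM to 12000 nM.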

Compound 3, half-maximal inhibitory concentration: 2760 nM
Estimate against measurement, compound 3: 1.3-fold (0.10 log units) above, and the stated range covers the measured number.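

In this assay, the replacement of 3-(dimethylamino)propyl by 3-(4-methylpiperazin-1-yl)propyl gives the series its first readable step at this position: a 1.5-fold lower number from compound 2 to compound 3 (0.18 log units; within the scatter). On these two numbers, the end of this chain accommodates a six-membered non-aromatic ring with 2 hetero atoms, 7 heavy atoms in place of 3, with no separation of compound 3 from compound 2 beyond the usual scatter. No measurement is available that bears on the reason for this result.

The compounds shown leave open whether the insensitivity extends to other end groups on the same chain, such as morpholin-4-yl, a primary amine or a carboxylic acid, and whether a longer chain, such as 4-(dimethylamino)butyl, also keeps a measurable value. They also leave open whether the 2-(4-methylpiperazin-1-yl)ethyl chain gives a number at all, since compound 1, which carries 2-(dimethylamino)ethyl, is recorded as "not active" (no number reported).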